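Swapping the aminophenyl for a dichlorophenyl on the enone

This account rests on a few compounds, and the source may have more. Where it says the series, first, only, none or still open, it means among the compounds named here.

Measured compounds:
compound 1 `COc1ccc(-c2cc(/C=C/C(=O)c3ccc(N)cc3)[nH]n2)cc1` gives -94%
compound 2 `COc1cc(-c2cc(/C=C/C(=O)c3ccc(N)cc3)[nH]n2)cc(OC)c1OC` gives -99%

Both compounds were tested in a functional assay on SF-539 cells (Homo sapiens) for cytotoxicity, read by sulforhodamine B assay, with a stated time of 48 h, tested at 100 uM; a higher number here means a weaker effect of the compound at the concentration tested, a lower number a stronger effect. Compound 1 gives -94% and compound 2 gives -99%. These two numbers lie within the usual scatter of each other, so neither compound can be told apart from the other on these data; compound 2 simply sits at the same strongly negative level as compound 1.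

Compound 3 `COc1cc(-c2cc(/C=C/C(=O)c3ccc(Cl)c(Cl)c3)[nH]n2)cc(OC)c1OC` has not yet been measured in this assay. It differs from compound 2 in one place: 3,4-dichlorophenyl in place of 4-aminophenyl on a carbonyl carbon. Among the compounds with values here, no measured pair shows what this kind of change does in this assay, so the size and direction of the step cannot be read from the data. Going by these compounds, the two measured compounds both keep the 4-aminophenyl, and compound 2 reaches a very negative number with it; what the 3,4-dichlorophenyl does is unknown.

The number for compound 3 is therefore estimated with a wide range, allowing a weaker effect than compound 2, as the step of a number 29 percentage points higher from compound 2 to compound 3 (beyond the scatter). Compound 3 is expected to give about -70%, between -100% and -5%.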

Compound 3, a percentage reported as activity, at one concentration (the size of the read-out at that concentration, not a potency): -74%
Compound 3: middle estimate off by 4 percentage points, on the high side, and the stated range covers the measured number.
By their numbers in this assay, from the lowest: compounds 2 and 1 (each within the scatter of the next); then compound 3.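

This is the first change shown on the carbonyl carbon, since compound 1 and compound 2 both carry 4-aminophenyl there, and in this assay the swap to 3,4-dichlorophenyl gives a number 25 percentage points higher from compound 2 to compound 3 (beyond the scatter). The group at this place therefore does affect the read-out, and the change to 3,4-dichlorophenyl weakens the effect at the concentration tested, though the number stays well below zero: compound 3 gives -74%. So, in this one pair, 4-aminophenyl is not needed for a strongly negative number, and no measurement here accounts for the size of the step.

The swap removes the amine and adds two chlorines in a single move, so the compounds shown cannot say which of these matters, and a plain phenyl, a 4-chlorophenyl or a 4-hydroxyphenyl at the same place would help to separate the two. They also leave open whether the step would be the same size on the core of compound 1, and, as each number comes from one concentration, how the effects of the compounds compare at other concentrations.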